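The source may hold more compounds than are shown below. What is called first, only, known or untested is meant among the compounds shown, and "the series" means these compounds.

Measured in a functional assay on U-251 cells (Homo sapiens) for cytotoxicity, read by MTT assay, with a stated time of 48 h (on this read-out higher numbers stand for weaker inhibition of growth and lower numbers for stronger inhibition of growth), so far
compound 1 `O=C(NO)N1CCN(C(=S)N/N=C/c2ccccc2O)CC1` gives 14300 nM
compound 2 `O=C(NO)N1CCN(C(=S)N/N=C/c2ccccc2Cl)CC1` gives 13500 nM

Compound 2 stands level with compound 1 within the scatter, so the two numbers do not yet separate the series. Next is compound 3 `Cc1ccc(/C=N/NC(=S)N2CCN(C(=O)NO)CC2)cc1`, which differs from compound 2 as follows (4-methylphenyl in place of 2-chlorophenyl on a carbon with a double bond to nitrogen), with 4-methylphenyl in place of 2-chlorophenyl on a carbon with a double bond to nitrogen. Within the data shown here, only one measured step bears on this change, a 1.1-fold lower number from compound 1 to compound 2 (0.03 log units; within the scatter), where chloro replaced hydroxy on an aromatic carbon and the number stayed within the scatter. Among the measured compounds shown here, no measured compound carries 4-methylphenyl, so this support is thin. No step beyond the scatter is expected in this assay, in either direction. The expected change is a 1.0-fold lower number from compound 2 to compound 3 (0.02 log units; within the scatter). For compound 3 the estimated value is 13000 nM, with an expected range from 6000 nM to 28000 nM.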

Compound 3, concentration for 50% growth inhibition: 27500 nM
For compound 3 the middle estimate is 2.1-fold (0.33 log units) below the measured one, and the stated range covers the measured number.
By their numbers in this assay, from the lowest: compounds 2, 1 and 3 (each within the scatter of the next, the first and the last beyond it).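

In this assay, the position on the carbon with a double bond to nitrogen gives its first step beyond the scatter, a modest one, when 4-methylphenyl replaces 2-chlorophenyl (a 2.0-fold higher number from compound 2 to compound 3 (0.31 log units; beyond the scatter)). Against 2-hydroxyphenyl, the same entering group stays within the scatter (a 1.9-fold higher number from compound 1 to compound 3 (0.28 log units; within the scatter)), so the position's response to 4-methylphenyl is visible in only one of the two comparisons and does not yet amount to a trend. No measurement available here accounts for the step.

Still open, from the compounds shown here alone, is whether the step follows the identity of the substituent or its place on the phenyl ring, as 2-chlorophenyl and 4-methylphenyl differ in both, and a pair such as 4-chlorophenyl and 2-methylphenyl would separate the two. Also open, going by these compounds, is how this position responds to a phenyl ring carrying an amine or a carboxylic acid.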